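Acetyl to Dimethylamino on a Pyrazole-Based Growth Inhibitor

A few compounds are considered here, and "the series" means these few. Any claim that something is new, unique, unknown or untested is made for them only; others in the source may bear on it.

Measured compounds:
compound 1 `COc1cc(C)cc(-c2c(-c3ccnc(-c4ccc(C(C)=O)cc4)c3)cnn2CC#N)c1`: 5680 nM
compound 2 `COc1cc(C)cc(-c2nn(CC#N)cc2-c2ccc(-c3cccc(C(C)=O)c3)nc2)c1`: 3870 nM

In a functional assay on Hs-578T cells (Homo sapiens) for inhibition, read by sulforhodamine B assay, with a stated time of 48 h (on this read-out lower numbers stand for stronger inhibition of growth and higher numbers for weaker inhibition of growth), compound 1 gives 5680 nM. In this assay compound 2 gives 3870 nM. Compound 1 has the higher of the two numbers, but the gap to compound 2 lies within the scatter of repeated measurements, so the two compounds cannot be told apart on these values.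

Compound 3 `COc1cc(C)cc(-c2c(-c3ccnc(-c4ccc(N(C)C)cc4)c3)cnn2CC#N)c1` differs from compound 1 in one place: dimethylamino in place of acetyl on an aromatic carbon. Going by the values given here, no comparison of measured compounds shows what such a change does here, so the step from compound 1 to compound 3 is expected to stay within the scatter, with no clear direction, as the expected step of a 1.2-fold lower number from compound 1 to compound 3 (0.07 log units; within the scatter) shows. Compound 3 is therefore expected to give about 4800 nM in this assay, with a range from 1500 nM to 15000 nM.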

Compound 3, concentration for total growth inhibition: > 100000 nM
Compound 3: a limit, no number (the forecaster's own chance of this, stated with the estimate: 5%); at least 20-fold (1.31 log units) between middle value and limit.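

At this place, on an aromatic carbon para to a large group, the exchange of acetyl for dimethylamino is far from neutral in this assay: the change gives an at least 17-fold higher number from compound 1 to compound 3 (1.24 log units; beyond the scatter). The earlier compounds shown here both carry acetyl, so they gave no view of a change here, and this step appears even though the two groups have the same count of heavy atoms and of hydrogen-bond acceptors. For compound 3 the printed value is a limit of the assay and not a number: the limit of > 100000 nM in this assay, at which 1 of the 3 values shown sits.

The compounds shown leave open whether the loss goes with dimethylamino itself or with the removal of acetyl, as a primary amine, a methoxy group or a carboxylic acid at this place is not among them. Nor do they show whether the same change would act alike on compound 2.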